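The compounds below may be only part of what the source reports. "The series", "measured", "known", "first", "only" and "open" are said of these compounds alone.

Measured compounds:
compound 1, `CCCOC(=O)c1c(C)coc1-c1ccc2c(CC)cccc2c1OC`: in a functional assay on ZR-75-1 cells (Homo sapiens) for cytotoxicity, read by MTT assay, with a stated time of 72 h (on this read-out lower numbers stand for an effect already at smaller amounts and higher numbers for an effect only at larger amounts of compound), compound 1 gives > 10 ug/mL, a limit of the assay.
compound 2, `CCc1cccc2c(OC)c(-c3occ(C)c3C(=S)OC)ccc12`: in this assay compound 2 gives 5.8 ug/mL.
compound 3, `CCc1cccc2c(OC)c(-c3occ(C)c3CO)ccc12`: in this assay compound 3 gives > 10 ug/mL, a limit of the assay.

Compound 3 thus stands at the limit, where two of the three values sit (the limit of > 10 ug/mL in this assay, at which 2 of the 3 values shown sit). Compound 4, `CCOCc1c(C)coc1-c1ccc2c(CC)cccc2c1OC`, differs from compound 3 by ethyl in place of hydrogen on an oxygen on a saturated carbon. For the measured compounds named here, the steps that bear on this are an at least 1.7-fold higher number from compound 2 to compound 3 (0.23 log units; that floor lies within the scatter) and a step that the two limits leave unreadable from compound 1 to compound 3. Going by the values given here, neither touches the oxygen of the hydroxymethyl, and no measured compound carries an ethyl on that oxygen. Compound 1 sits at the same limit. Compound 4 is therefore expected to remain at or near that limit, with the step that the limit leaves unreadable from compound 3 to compound 4 expected to be none beyond the scatter. Compound 4 is estimated at 15 ug/mL, ranging from 6 ug/mL to 40 ug/mL.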

Compound 4, concentration for half-maximal effect: 9.1 ug/mL
For compound 4 the middle estimate is 1.6-fold (0.22 log units) above the measured one; measured number inside the range.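

In this assay ethyl on the oxygen of the hydroxymethyl yields a number instead of a limit: compound 4 gives 9.1 ug/mL, with an at least 1.0-fold lower number from compound 3 to compound 4 (0.04 log units; that floor lies within the scatter). Against propoxycarbonyl the reading is likewise only a floor, an at least 1.0-fold lower number from compound 1 to compound 4 (0.04 log units; that floor lies within the scatter). With a 1.6-fold higher number from compound 2 to compound 4 (0.20 log units; within the scatter), ethoxymethyl is not told apart from the group of compound 2 at this position.

On these data alone, the true size of the two floor steps stays open, the values of compound 1 and compound 3 being limits: the limit of > 10 ug/mL in this assay, at which 2 of the 4 values shown sit. Whether a longer chain on this oxygen, or an amine in its place, moves the number beyond the scatter also stays open.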